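Hydroxyphenyl placement and cytotoxicity in a small series

The source may hold more compounds than are shown below. What is called first, only, known or untested is meant among the compounds shown, and "the series" means these compounds.

Measured so far:
Compound 1 `Oc1cccc(-c2cc(-c3ccsc3)cc(-c3ccccc3O)n2)c1`: in a functional assay on HCT-15 cells (Homo sapiens) for cytotoxicity, read by CCK-8 assay (a higher number here means a weaker inhibitor, a lower number a stronger inhibitor), compound 1 gives > 50000 nM, which is a limit of the assay.
Compound 2 `Oc1cccc(-c2cc(-c3ccsc3)cc(-c3cccc(O)c3)n2)c1`: in this assay compound 2 gives 1630 nM.
Compound 3 `Oc1ccccc1-c1cc(-c2ccoc2)cc(-c2ccccc2O)n1`: in this assay compound 3 gives > 50000 nM, which is a limit of the assay.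

Among the measured compounds shown here, the one counted change between the measured pair is 3-hydroxyphenyl in place of 2-hydroxyphenyl on an aromatic carbon. It gave an at least 30-fold lower number from compound 1 to compound 2 (1.48 log units; beyond the scatter). The step starts from the limit noted in the limit of > 50000 nM in this assay, at which 2 of the 3 values shown sit, so only its lower bound is known.

Compound 4 `Oc1cccc(-c2cc(-c3ccoc3)cc(-c3ccccc3O)n2)c1` is not yet measured. It differs from compound 3 by 3-hydroxyphenyl in place of 2-hydroxyphenyl on an aromatic carbon, the same kind of change as that from compound 1 to compound 2, though the surroundings of the place are not identical: in the measured pair the carbon carrying the change is meta to a 3-hydroxyphenyl group and meta to a thiophen-3-yl group, whereas in compound 3 it is meta to a 2-hydroxyphenyl group and meta to a furan-3-yl group. How the core of compound 3 differs from the core of compound 1 is not broken down here.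

Compound 3 sits at the limit recorded in the limit of > 50000 nM in this assay, at which 2 of the 3 values shown sit, as compound 1 does. Since the measured step was large, a step of comparable direction is expected from compound 3 to compound 4, estimated as an at least 16-fold lower number from compound 3 to compound 4 (1.22 log units; beyond the scatter), resting on an at least 30-fold lower number from compound 1 to compound 2 (1.48 log units; beyond the scatter) and on the value of compound 2 1630 nM as the closest measured analogue. Compound 4 is therefore estimated at 3000 nM, within a range from 800 nM to 20000 nM.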

Compound 4, half-maximal inhibitory concentration: > 50000 nM
Compound 4 ended at the assay's limit (the forecaster's own chance of this, stated with the estimate: 25%); middle value at least 16-fold (1.22 log units) from the limit.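

In this assay compound 4 gives > 50000 nM, which is a limit of the assay. Among the compounds shown here, no step to compound 4 from compound 1 or compound 3 can be read, because all three compounds sit at the same limit: the limit of > 50000 nM in this assay, at which 3 of the 4 values shown sit. The compounds shown leave open whether furan-3-yl in place of thiophen-3-yl would change the number in a compound carrying two 3-hydroxyphenyl groups, as compound 2 does.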